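The compounds below may be only part of what the source reports. "The series", "measured", "known", "first", "only" and "open" are said of these compounds alone.

Two sulfonamides built on a benzoxazole-bearing core have been tested for tolerance by HEK293 cells. Compound 1 `O=S(=O)(Nc1ccc(-c2nc3ccccc3o2)cc1)c1cccc(Cl)c1` gives only a limit in an ADME assay on HEK293 cells (Homo sapiens) for cytotoxicity, read by resazurin assay, with a stated time of 48 h (a higher number here means that more compound is tolerated, a lower number that less compound is tolerated), namely > 100000 nM. Among the compounds with values here, compound 2 `O=S(=O)(Nc1ccc2oc(-c3ccccc3)nc2c1)c1ccccc1F`, in which the sulfonamide sits on the core and the sulfonyl carries a 2-fluorophenyl group, yields the one numerical reading in this assay, 72000 nM, so it stands as the sole fixed point among the values shown, the other being (the limit of > 100000 nM in this assay, at which 1 of the 2 values shown sits). Compound 3 `O=S(=O)(Nc1ccc2oc(-c3ccccc3)nc2c1)c1ccc(O)cc1` is the next compound to be measured. It differs from compound 2 in one place only (4-hydroxyphenyl in place of 2-fluorophenyl on a sulfonyl sulfur). Within the data shown here, since the two measured compounds differ in more than one place, no measured step is available to guide the expectation. Compound 3 is therefore expected to stay close to compound 2 in this assay, with a step of a 1.2-fold higher number from compound 2 to compound 3 (0.07 log units; within the scatter) that lies within the usual scatter, and its value is estimated at 85000 nM, between 35000 nM and 200000 nM.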

Compound 3, half-maximal cytotoxic concentration: > 100000 nM
Compound 3: a limit, no number; the forecaster's own chance of this, stated with the estimate: 45%; at least 1.1-fold (0.07 log units) between middle value and limit.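

In this assay, 4-hydroxyphenyl in place of 2-fluorophenyl on a sulfonyl sulfur gives an at least 1.3-fold higher number from compound 2 to compound 3 (0.14 log units; that floor lies within the scatter), so the change is not shown to alter tolerance. This is the only pair shown that differs in one place, and it indicates that a group with a hydrogen-bond donor and a hydrogen-bond acceptor can stand on the sulfonyl sulfur with no drop in the tolerated concentration. The reading for compound 3 is a limit and not a number, and such limits now make up most of the readings: the limit of > 100000 nM in this assay, at which 2 of the 3 values shown sit.

As far as these compounds go, how large the step really is stays open, as compound 3 has no number. Also open, from the compounds shown here alone, is whether an amine or a carboxylic acid in place of the hydroxyl, or a longer chain on the sulfonyl sulfur, would give a reading with a fixed number.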